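The source may report more compounds than this note shows. Statements on the series, on what has been measured and on what is new or still open speak of the compounds shown alone.

Measured so far in a functional assay on B16-F10 cells (Mus musculus) for antiproliferative activity, read by MTT assay, with a stated time of 48 h; a lower number here means a stronger inhibitor, a higher number a weaker inhibitor:
Compound 1 `COc1ccc(/C=C/c2cc(OC)cc(OC)c2/C=C/C(=O)c2ccc(Cl)cc2)cc1`: 4.9 ug/mL
Compound 2 `COc1ccc(/C=C/c2cc(OC)cc(OC)c2/C=C/C(=O)c2ccc(C)cc2C)cc1`: 4 ug/mL
Compound 3 `COc1ccc(/C=C/c2cc(OC)cc(OC)c2/C=C/C(=O)c2ccc(OC)cc2)cc1`: 5.8 ug/mL

The three values lie close together. Compound 3, at 5.8 ug/mL, sits within the scatter of both compound 1 and compound 2, so these numbers set no clear order. The unmeasured compound 4 `COc1ccc(/C=C/c2cc(OC)cc(OC)c2/C=C/C(=O)c2ccc(C)c(C)c2)cc1` keeps the shared core and changes one group: 3,4-dimethylphenyl in place of 4-methoxyphenyl on a carbonyl carbon.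

The closest guide is compound 2, which also carries a dimethylphenyl group on the carbonyl carbon. Exchanging that group for 4-methoxyphenyl gave a 1.5-fold higher number from compound 2 to compound 3 (0.16 log units; within the scatter). Replacing chloro with methoxy gave a 1.2-fold higher number from compound 1 to compound 3 (0.07 log units; within the scatter), and the remaining pair shows a 1.2-fold lower number from compound 1 to compound 2 (0.09 log units; within the scatter). All three steps stay within the scatter, so none separates these groups in this assay. Going by the values given here, no measured compound carries the 3,4-dimethylphenyl group itself.

A change beyond the scatter is therefore not expected, with only a slight lean toward the value of compound 2 (4 ug/mL). The estimated step is a 1.3-fold lower number from compound 3 to compound 4 (0.10 log units; within the scatter), which is no more than a small expected shift. Compound 4 is estimated at 4.6 ug/mL, with an expected range from 2.8 ug/mL to 7.5 ug/mL.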

Compound 4, half-maximal inhibitory concentration: 1.4 ug/mL
Beside the measured number, compound 4's estimate is 3.3-fold (0.52 log units) above it; measured number outside the range, below it.
By their numbers in this assay, from the lowest: compound 4; then compounds 2, 1 and 3 (each within the scatter of the next).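

In this assay the group on the carbonyl carbon proved able to move the number beyond the scatter, which none of the steps among the earlier compounds had shown: 3,4-dimethylphenyl gives a 4.1-fold lower number from compound 3 to compound 4 (0.62 log units; beyond the scatter) and a 2.9-fold lower number from compound 2 to compound 4 (0.46 log units; beyond the scatter) as well as a 3.5-fold lower number from compound 1 to compound 4 (0.54 log units; beyond the scatter) and so stands apart from all three earlier groups. The step from the 2,4-dimethylphenyl group shows that the presence of two methyl groups on the ring does not by itself give the lower number, since the two compounds differ only in where those methyl groups stand. Nothing available here accounts for this difference.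

From the compounds shown here alone, what remains open is how much of the result depends on both methyl groups together, and whether a single methyl group, an ethyl group in place of either methyl, or an amine on the same ring would keep the lower number. Going by these compounds, it is also open whether the 3,4-dimethylphenyl group would stand apart in the same way with any change to the rest of the shared core or in cells other than those of this assay.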